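Swapping a hydroxyphenyl for a hydroxyethyl group

The source may hold more compounds than are shown below. What is called first, only, known or untested is meant among the compounds shown, and "the series" means these compounds.

Three compounds sharing one core were tested in a functional assay on CFPAC-1 cells (Homo sapiens) for antiproliferative activity, read by MTT assay, with a stated time of 72 h; a lower number here means a stronger inhibitor, a higher number a weaker inhibitor. Compound 1 `O=C1O[C@H]([C@@H](O)Cn2cc(-c3ccc(Br)cc3)nn2)C(OCc2ccccc2)=C1OCc1ccccc1` gives 5830 nM, compound 2 `O=C1O[C@H]([C@@H](O)Cn2cc(-c3cccc(O)c3)nn2)C(OCc2ccccc2)=C1OCc1ccccc1` gives 54100 nM, and compound 3 `CCCCCCCCCCc1cn(C[C@H](O)[C@H]2OC(=O)C(OCc3ccccc3)=C2OCc2ccccc2)nn1` gives 40300 nM. Compound 2 thus shows the highest number of the three: the step of a 9.3-fold higher number from compound 1 to compound 2 (0.97 log units; beyond the scatter) lies beyond the scatter, whereas a 1.3-fold lower number from compound 2 to compound 3 (0.13 log units; within the scatter) does not. Compound 4 `O=C1O[C@H]([C@@H](O)Cn2cc(CCO)nn2)C(OCc2ccccc2)=C1OCc1ccccc1` differs from compound 2 in one place: 2-hydroxyethyl in place of 3-hydroxyphenyl on an aromatic carbon. Among the compounds with values here, no measured step makes this exact change, so the nearest guide is the step that replaced the same group. Because the step of a 1.3-fold lower number from compound 2 to compound 3 (0.13 log units; within the scatter) changed little, compound 4 is expected to stay close, with a 1.1-fold lower number from compound 2 to compound 4 (0.03 log units; within the scatter) estimated within the scatter and a value estimated at 50000 nM (range 15000 nM to 150000 nM).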

Compound 4, half-maximal inhibitory concentration: > 100000 nM
Compound 4: no number, only a limit (the forecaster's own chance of this, stated with the estimate: 15%); middle value at least 2.0-fold (0.30 log units) from the limit.
By their numbers in this assay, from the lowest: compound 1; then compounds 3 and 2 (each within the scatter of the next). At a limit, above all of these: compound 4.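

In this assay compound 4 gives > 100000 nM, a limit of the assay and not a number. Against the larger groups the short 2-hydroxyethyl group clearly does worse, with an at least 17-fold higher number from compound 1 to compound 4 (1.23 log units; beyond the scatter) and an at least 2.4-fold higher number from compound 3 to compound 4 (0.39 log units; beyond the scatter). Its swap for the similarly hydroxylated 3-hydroxyphenyl stays unsettled, however, with an at least 1.8-fold higher number from compound 2 to compound 4 (0.26 log units; that floor lies within the scatter), so a ring at this position is not shown to matter on its own. As far as these compounds go, it remains open whether a hexyl chain or a 2-aminoethyl group here would bring back a measurable number.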